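The source may hold more compounds than are shown below. What is called first, only, known or untested is meant among the compounds shown, and "the series" means these compounds.

Values in a functional assay on Daoy cells (Homo sapiens) for antiproliferative activity, read by trypan blue exclusion and crystal violet staining, with a stated time of 72 h; a higher number here means a weaker inhibitor, a lower number a stronger inhibitor:
- compound 1 `CCCC(=O)NC(c1ccc(C)cc1)c1cc(Cl)c2cccnc2c1O`: 100 nM
- compound 2 `CCCC(=O)NC(c1ccc(Cl)cc1)c1cc(Cl)c2cccnc2c1O`: 100 nM
- compound 3 `CCCC(=O)NC(c1ccc(N(CC)CC)cc1)c1cc(Cl)c2cccnc2c1O`: 100 nM

Compound 3 stands level with compound 1 and compound 2 at the digits available. Among the compounds with values here, the next entry, compound 4 `CCCC(=O)NC(c1ccc(C(C)C)cc1)c1cc(Cl)c2cccnc2c1O`, has no measurement yet in this assay. It carries isopropyl in place of diethylamino on an aromatic carbon, para to a large group: isopropyl in place of diethylamino on an aromatic carbon.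

Within the data shown here, three measured steps bear on this change, each exchanging the group on that same aromatic carbon. They are no change at the digits printed from compound 1 to compound 2 (within the scatter), no change at the digits printed from compound 1 to compound 3 (within the scatter) and no change at the digits printed from compound 2 to compound 3 (within the scatter). All three lie within the scatter, and none of the three compounds goes against this flat picture. It covers only methyl, chloro and diethylamino, and isopropyl has not been measured on the shared core, so some uncertainty remains.

The expectation rests on compound 3 at 100 nM and on the flat steps around it. No step beyond the scatter is expected in this assay, in either direction. The estimated step is no change at the digits printed from compound 3 to compound 4 (within the scatter). The expected value for compound 4 is 100 nM, within an estimated range of 50 nM to 220 nM.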

Compound 4, half-maximal inhibitory concentration: 90 nM
Compound 4: the middle estimate sits 1.1-fold (0.05 log units) above what was measured, and the stated range covers the measured number.
By their numbers in this assay, from the lowest: compounds 4, 1, 2 and 3 (each within the scatter of the next).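

In this assay, isopropyl in place of diethylamino on this aromatic carbon, para to a large group, gives a 1.1-fold lower number from compound 3 to compound 4 (0.05 log units; within the scatter), so the read-out stays flat when the nitrogen and its hydrogen-bond acceptor leave and the substituent goes from 5 heavy atoms to 3. Isopropyl also matches the two other groups at this place, with a 1.1-fold lower number from compound 2 to compound 4 (0.05 log units; within the scatter) for the exchange with chloro and a 1.1-fold lower number from compound 1 to compound 4 (0.05 log units; within the scatter) for the exchange with methyl, which puts all four substituents on the shared core within the scatter of one another. Nothing available accounts for this flat picture.

As far as these compounds go, whether a carboxylic acid, a primary amine, a longer chain or a substituent containing a ring on this aromatic carbon would stay at the same level remains open. All four compounds share the rest of the structure, so they also leave open how this assay would respond to changes elsewhere on the core, including the butanamide chain, the chloro on the core and the hydroxyl.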